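A few compounds are considered here, and "the series" means these few. Any claim that something is new, unique, unknown or untested is made for them only; others in the source may bear on it.

In a physicochemical assay for acid dissociation, compound 1 `Cc1cc(C)nc(NS(=O)(=O)c2ccc(NC3=C(Cl)C(=O)c4ccccc4C3=O)cc2)n1` gives < 7.91, which is a limit and not a number. Compound 2 `Cc1cc(NS(=O)(=O)c2ccc(NC3=C(Cl)C(=O)c4ccccc4C3=O)cc2)no1` gives < 7.91, which is also a limit. The picture so far is therefore (the limit of < 7.91 in this assay, at which 2 of the 2 values shown sit). Within the data shown here, the only measured step is a step that the two limits leave unreadable from compound 1 to compound 2, so it offers neither a size nor a direction. Compound 3 `Cc1nnc(NS(=O)(=O)c2ccc(NC3=C(Cl)C(=O)c4ccccc4C3=O)cc2)s1` changes the same place: 5-methyl-1,3,4-thiadiazol-2-yl in place of 4,6-dimethylpyrimidin-2-yl on a sulfonamide nitrogen. Here, 5-methyl-1,3,4-thiadiazol-2-yl stands in place of 4,6-dimethylpyrimidin-2-yl on a sulfonamide nitrogen. With no readable step to build on, any expectation in this assay remains loose and has no firm direction. The expected change is a step that the limit leaves unreadable from compound 1 to compound 3, a rough estimate. For compound 3 the estimated value is 6.8, with an expected range from 5.5 to 7.9.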

Compound 3, acid dissociation constant: < 7.91
Compound 3 was reported as a limit; the forecaster's own chance of this, stated with the estimate: 65%; the middle value is on the limit's open side.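

In this assay compound 3 gives < 7.91, which is a limit and not a number. No step among compound 1, compound 2 and compound 3 can be read, in size or in direction: the limit of < 7.91 in this assay, at which 3 of the 3 values shown sit.

From the compounds shown here alone, what stays open is the actual value of each compound, and whether the three groups on the sulfonamide nitrogen differ at all in this read-out.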